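From 2-methoxyphenyl to 4-bromophenyl on the amine nitrogen

The source may hold more compounds than are shown below. What is called first, only, known or untested is meant among the compounds shown, and "the series" means these compounds.

In a functional assay on MCF7 cells (Homo sapiens) for inhibition, read by sulforhodamine B assay (on this read-out lower numbers stand for stronger inhibition and higher numbers for weaker inhibition), compound 1 (`CCc1ccc(NC2=CC(=O)c3nc4n(c3C2=O)[C@H]2OC[C@@H](O)[C@H]2OC4)cc1`) gives 960 nM as a measured number. Compound 2 (`COc1ccccc1NC1=CC(=O)c2nc3n(c2C1=O)[C@H]1OC[C@@H](O)[C@H]1OC3`) gives > 4000 nM as a limit of the assay and not a number. Compound 2 thus stands at the limit of > 4000 nM in this assay, at which 1 of the 2 values shown sits, and has no exact place in the series. Compound 3 (`O=C1C=C(Nc2ccc(Br)cc2)C(=O)c2c1nc1n2[C@H]2OC[C@@H](O)[C@H]2OC1`) differs from compound 2 by 4-bromophenyl in place of 2-methoxyphenyl on an amine nitrogen. For the measured compounds named here, one measured step bears on this: an at least 4.1-fold higher number from compound 1 to compound 2 (0.61 log units; beyond the scatter) which lies beyond the scatter and brought in the same 2-methoxyphenyl in place of 4-ethylphenyl. Compound 3 carries 4-bromophenyl where compound 1 has 4-ethylphenyl, so a step of comparable size toward lower numbers in this assay is expected, on the evidence of one pair only. Compound 1 at 960 nM is the closest guide. The expected step is an at least 3.0-fold lower number from compound 2 to compound 3 (0.48 log units; beyond the scatter) by this estimate. Estimated for compound 3: 1300 nM with 400 nM to 3800 nM as the expected range.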

Compound 3, half-maximal inhibitory concentration: 2580 nM
Compound 3: the middle estimate sits 2.0-fold (0.30 log units) below what was measured; measured number inside the range.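

Bromo in place of ethyl on an aromatic carbon gives a 2.7-fold higher number from compound 1 to compound 3 (0.43 log units; beyond the scatter) in this assay, so this small change on the phenyl ring of the amine nitrogen already moves the read-out, though only modestly. 4-Bromophenyl in place of 2-methoxyphenyl on the amine nitrogen gives an at least 1.5-fold lower number from compound 2 to compound 3 (0.19 log units; that floor lies within the scatter), and as that floor lies within the scatter, this pair alone does not establish a gain. Compound 2 carries a limit and not a number, and the true size of this step stays unknown because of it: the limit of > 4000 nM in this assay, at which 1 of the 3 values shown sits.

Compound 2 and compound 3 differ in both the group and its printed number on the phenyl ring, so a 4-methoxyphenyl on the amine nitrogen would be needed to separate those two. As far as these compounds go, whether a chloro group or a longer chain in place of the bromo or ethyl would give lower numbers remains open.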